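Benzothiophene in place of methylthiophene on a pyrimidine core

This account rests on a few compounds, and the source may have more. Where it says the series, first, only, none or still open, it means among the compounds named here.

Compounds measured in a functional assay on Jurkat cells for inhibition of nuclear factor NF-kappa-B complex (Homo sapiens); a higher number here means a weaker inhibitor, a lower number a stronger inhibitor:
Compound 1, `CCOC(=O)c1cnc(C(F)(F)F)nc1NN1C(=O)C=C(C)C1=O`, gives 1000 nM.
Compound 2, `CCOC(=O)c1cnc(-c2csc(C)n2)nc1NN1C(=O)C=C(C)C1=O`, gives 8000 nM.
Compound 3, `CCOC(=O)c1cnc(-c2ccc(C)s2)nc1NN1C(=O)C=C(C)C1=O`, gives 200 nM.

Among these three, compound 3 stands at the lowest number in this assay: the step of a 5.0-fold lower number from compound 1 to compound 3 (0.70 log units; beyond the scatter) and the step of a 40-fold lower number from compound 2 to compound 3 (1.60 log units; beyond the scatter) both lie beyond the scatter, so compound 3 is the strongest inhibitor of the set. The other comparison, an 8.0-fold higher number from compound 1 to compound 2 (0.90 log units; beyond the scatter), shows that the 2-methyl-1,3-thiazol-4-yl group gives a weaker inhibitor than the trifluoromethyl group.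

Compound 4, `CCOC(=O)c1cnc(-c2cc3ccccc3s2)nc1NN1C(=O)C=C(C)C1=O`, has not yet been measured. It differs from compound 3 by 1-benzothiophen-2-yl in place of 5-methylthiophen-2-yl on an aromatic carbon. Within the data shown here, none of the measured steps replaces one sulfur-containing five-membered ring with a larger fused one; the closest information is that a 40-fold lower number from compound 2 to compound 3 (1.60 log units; beyond the scatter) and a 5.0-fold lower number from compound 1 to compound 3 (0.70 log units; beyond the scatter) favour the 5-methylthiophen-2-yl group over the alternatives tried. Since compound 4 keeps a five-membered sulfur-containing aromatic ring at the same place, the expected step of a 1.5-fold higher number from compound 3 to compound 4 (0.18 log units; within the scatter) in this assay is small and uncertain in direction. Compound 4 is therefore estimated at 300 nM, within a range from 80 nM to 1200 nM.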

Compound 4, half-maximal inhibitory concentration: 4000 nM
Estimate against measurement, compound 4: 13-fold (1.12 log units) below; the measured number lies above the stated range.
By their numbers in this assay, from the lowest: compound 3; then compound 1; then compounds 4 and 2 (each within the scatter of the next).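

In this assay, the step of a 20-fold higher number from compound 3 to compound 4 (1.30 log units; beyond the scatter) shows that this position, on an aromatic carbon between two ring nitrogen atoms, does not accept every group built on a five-membered aromatic ring with sulfur: replacing 5-methylthiophen-2-yl with 1-benzothiophen-2-yl gives up the advantage held by compound 3. The change also leaves the fused group behind trifluoromethyl, with a 4.0-fold higher number from compound 1 to compound 4 (0.60 log units; beyond the scatter), whereas a 2.0-fold lower number from compound 2 to compound 4 (0.30 log units; within the scatter) stays within the scatter, so 1-benzothiophen-2-yl and 2-methyl-1,3-thiazol-4-yl cannot be told apart in this assay. The low number of compound 3 therefore goes with the 5-methylthiophen-2-yl group specifically, not with sulfur-containing aromatic rings at this place in general, although nothing available here accounts for the size of this step.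

The change removes the methyl and adds the six-membered aromatic ring at once, so the compounds shown leave open which of the two matters; an unsubstituted thiophen-2-yl group or a phenyl group at this place would separate them. They also leave open how this position responds to a group of a different kind, such as an amine or a carboxylic acid.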